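Aromatic carbonyl substituents on the amide of the shared core

The compounds below may be only part of what the source reports. "The series", "measured", "known", "first", "only" and "open" are said of these compounds alone.

Compound 3 `O=C(c1ccco1)N1CCCn2nc(COc3ccccc3)cc21` carries furan-2-yl on the carbonyl carbon. In a functional assay on HEK293 cells for positive allosteric modulation of metabotropic glutamate receptor 5 (Homo sapiens), read by calcium flux (on this read-out lower numbers stand for smaller maximal responses and higher numbers for larger maximal responses), compound 3 sits at a limit of the assay, < 15%, not at a number (the limit of < 15% in this assay, at which 1 of the 3 values shown sits). Its saturated neighbours do give numbers: compound 1 `O=C(C1CC1)N1CCCn2nc(COc3ccccc3)cc21` gives 61% and compound 2 `O=C(C1CCCC1)N1CCCn2nc(COc3ccccc3)cc21` gives 41%. The steps onto the aromatic ring were a number at least 46 percentage points lower from compound 1 to compound 3 (beyond the scatter) and a number at least 26 percentage points lower from compound 2 to compound 3 (beyond the scatter), so both moves from a cycloalkyl to furan-2-yl cut the largest response hard. Compound 4 `O=C(c1nccs1)N1CCCn2nc(COc3ccccc3)cc21` differs from compound 3 as follows: 1,3-thiazol-2-yl in place of furan-2-yl on a carbonyl carbon. For the measured compounds named here, no measured step compares two aromatic rings on this carbonyl carbon; only the two steps ending at compound 3 bear on it. The expected step of a number no lower from compound 3 to compound 4 (the limit leaves the size open) is judged within the scatter. Compound 4 is expected at 15%, with a range from 5% to 35%.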

Compound 4, largest response reached (reported as percent of maximum), in percent of the reference or control that the assay uses: 24%
Compound 4: the middle estimate sits 9 percentage points below what was measured; the measured number falls inside the stated range.
By their numbers in this assay, from the lowest: compound 4; then compound 2; then compound 1. At a limit, below all of these: compound 3.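

Compound 3 remains at a limit of this assay, not at a number: the limit of < 15% in this assay, at which 1 of the 4 values shown sits. Compound 4 gives a real number for an aromatic ring on this carbonyl carbon, yet with a number at least 9 percentage points higher from compound 3 to compound 4 (that floor lies within the scatter), the two aromatic rings cannot be ranked. The cost of leaving the saturated rings now has a measured size, with a number 17 percentage points lower from compound 2 to compound 4 (beyond the scatter) and a number 37 percentage points lower from compound 1 to compound 4 (beyond the scatter).

As far as these compounds go, whether phenyl or an open-chain group such as isopropyl on this carbonyl carbon would keep the cycloalkyl response stays open. So does where cyclobutyl would fall.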